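Chalcone amides: trimming the acyl group to acetyl

The source may report more compounds than this note shows. Statements on the series, on what has been measured and on what is new or still open speak of the compounds shown alone.

Among the compounds with values here, compound 2 `COc1cc(/C=C/C(=O)c2cccc(NC(=O)c3ccc(Cl)c(Cl)c3)c2)ccc1O` gives 2.97 ug/mL in a functional assay on HUVEC cells (Homo sapiens) for inhibition (on this read-out higher numbers stand for weaker inhibition and lower numbers for stronger inhibition), and stands highest of the two numbers so far; compound 1 `COc1cc(/C=C/C(=O)c2cccc(NC(=O)c3ccc(Cl)cc3)c2)ccc1O` gives 0.76 ug/mL. Within the data shown here, the one measured step, a 3.9-fold higher number from compound 1 to compound 2 (0.59 log units; beyond the scatter), concerns a chloro on the aryl amide and is modest. Among the measured compounds shown here, compound 3 `COc1cc(/C=C/C(=O)c2cccc(NC(C)=O)c2)ccc1O` differs from compound 2 by methyl in place of 3,4-dichlorophenyl on a carbonyl carbon, a larger change for which no step is recorded, so the direction is uncertain. On balance the number for compound 3 is expected to move as a 1.5-fold lower number from compound 2 to compound 3 (0.17 log units; within the scatter), landing near 2 ug/mL with a range from 0.6 ug/mL to 7 ug/mL.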

Compound 3, half-maximal inhibitory concentration: 7.06 ug/mL
The estimate for compound 3 lay 3.5-fold (0.55 log units) below the measured number, outside the stated range (above it).
By their numbers in this assay, from the lowest: compound 1; then compound 2; then compound 3.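

In this assay, methyl in place of 3,4-dichlorophenyl on the carbonyl carbon gives a 2.4-fold higher number from compound 2 to compound 3 (0.38 log units; beyond the scatter), and methyl in place of 4-chlorophenyl gives a 9.3-fold higher number from compound 1 to compound 3 (0.97 log units; beyond the scatter). The aryl group at this position can therefore be exchanged only with a loss of inhibition in the compounds shown, and compound 3 is the weakest of the three. Nothing at hand accounts for this loss. The compounds shown carry only methyl and chlorinated phenyl groups on this carbonyl carbon. An unsubstituted phenyl, a longer alkyl chain or a chain ending in an amine would test whether the ring itself carries the difference.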